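A few compounds are considered here, and "the series" means these few. Any claim that something is new, unique, unknown or untested is made for them only; others in the source may bear on it.

Working notes on the diacylhydrazine series. In an assay on cells for agonist activity at ecdysone receptor (Bombyx mori), read by a luciferase reporter, with a stated time of 24 h (on this read-out lower numbers stand for an effect already at smaller amounts and higher numbers for an effect only at larger amounts of compound), compound 1 `CC(C)(C)N(NC(=O)c1ccc(F)cc1)C(=O)c1ccccc1Cl` gives 389 nM; compound 2 `CCc1ccc(C(=O)NN(C(=O)c2ccccc2Cl)C(C)(C)C)cc1` gives 5.75 nM in this assay; compound 3 `CCc1ccc(C(=O)NN(C(=O)c2ccccc2)C(C)(C)C)cc1` gives 4.9 nM in this assay, the lowest of the three numbers, though its gap to compound 2 is within the scatter. The two measured steps are a 68-fold lower number from compound 1 to compound 2 (1.83 log units; beyond the scatter) and a 1.2-fold lower number from compound 2 to compound 3 (0.07 log units; within the scatter). Compound 4 `CCOc1ccccc1C(=O)N(NC(=O)c1ccc(CC)cc1)C(C)(C)C` differs from compound 3 by ethoxy in place of hydrogen on an aromatic carbon. Within the data shown here, only the second step touches this position, and there the exchange of chloro for hydrogen moved the number by nothing beyond the scatter; no measured step covers ethoxy at this carbon. The expected step is therefore small, a 1.6-fold higher number from compound 3 to compound 4 (0.21 log units; within the scatter), within the scatter. Compound 4 is expected to give 8 nM in this assay, with a range from 2.5 nM to 40 nM.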

Compound 4, half-maximal effective concentration: 2880 nM
For compound 4 the middle estimate is 360-fold (2.56 log units) below the measured one, outside the stated range (above it).
By their numbers in this assay, from the lowest: compounds 3 and 2 (each within the scatter of the next); then compound 1; then compound 4.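

In this assay this aromatic carbon is not indifferent to its substituent: hydrogen and chloro sit within the scatter of each other, yet phenyl to 2-ethoxyphenyl gives a 590-fold higher number from compound 3 to compound 4 (2.77 log units; beyond the scatter), and ethoxy in place of chloro gives a 500-fold higher number from compound 2 to compound 4 (2.70 log units; beyond the scatter). The flat picture from the earlier step therefore holds only for those two groups. Nothing at hand bears on the reason for this jump. Open, going by these compounds, is how methyl, methoxy or a longer chain such as propoxy would read at this carbon, and whether the number rises gradually or abruptly across them.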